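A few compounds are considered here, and "the series" means these few. Any claim that something is new, unique, unknown or untested is made for them only; others in the source may bear on it.

Measured in an ADME assay on CHO cells (Cricetulus griseus) for cytotoxicity, read by LDH release; a higher number here means a weaker inhibitor, a lower number a stronger inhibitor:
- compound 1 `CC(Oc1ccc(Cl)cc1Cl)C(=O)N[C@H](C)c1ccc(F)cc1`: 97000 nM
- compound 2 `CCC(NC(=O)C(C)Oc1ccc(Cl)cc1Cl)c1ccc(F)cc1`: > 100000 nM

Compound 2 gives > 100000 nM, and this is a limit of the measurement, not a number. It sits at the limit of > 100000 nM in this assay, at which 1 of the 2 values shown sits, so its true position is not known. In this assay, among the measured compounds shown here, the only numerical reading is that of compound 1, at 97000 nM.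

The next compound, compound 3 `COC(=O)C(NC(=O)C(C)Oc1ccc(Cl)cc1Cl)c1ccc(F)cc1`, keeps the shared core of compound 2 but carries methoxycarbonyl in place of ethyl on a saturated chain carbon bound to an amide-type nitrogen and an aromatic carbon.

For the measured compounds named here, no step between measured compounds is available to size this change, so any expectation is a loose one. The reading of compound 1 at 97000 nM is the sole numerical anchor, and it gives no sign of a large shift among these close relatives. No change beyond the scatter is expected in this assay, in either direction. The expected step of a number no higher from compound 2 to compound 3 (the limit leaves the size open) is therefore small. For compound 3 the estimated value is 100000 nM. The expected range for compound 3 runs from 45000 nM to 160000 nM.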

Compound 3, half-maximal inhibitory concentration: > 100000 nM
Compound 3 was reported as a limit; the forecaster's own chance of this, stated with the estimate: 55%; the middle value lies on the limit itself.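

In this assay compound 3 gives > 100000 nM, which is a limit of the measurement and not a number. Compound 2 is also reported as a limit, so no step can be read from compound 2 to compound 3: the limit of > 100000 nM in this assay, at which 2 of the 3 values shown sit. The compounds shown leave open how far, if at all, methoxycarbonyl in place of ethyl shifts the true value.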